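Methylsulfanyl for methyl on the pyridine-type core of compound 1

A few compounds are considered here, and "the series" means these few. Any claim that something is new, unique, unknown or untested is made for them only; others in the source may bear on it.

Three amides built on one shared core have been tested in a functional assay on the whole organism for inhibition, with Rattus norvegicus as the target, at a dose of 10 mg/kg by the oral route; a lower number here means a weaker effect, a higher number a stronger effect of the compound at the dose given. Compound 1 `Cc1ccc(C(=O)Nc2nn[nH]n2)nc1` gives 42% in this assay and stands lowest of the three numbers. Compound 3 `CCCCc1ccnc(C(=O)Nc2nn[nH]n2)c1` gives 54%, the nearest to compound 1 and already beyond the scatter. Compound 2 `Cc1cccnc1C(=O)Nc1nn[nH]n1` gives 69%, the furthest from compound 1. No pair among these three differs in one place only, so no single step within the measured set can be read off; the three values stand side by side without a counted link.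

Compound 4 `CSc1ccc(C(=O)Nc2nn[nH]n2)nc1` is the next member to be measured in this assay. It differs from compound 1 in one place: methylsulfanyl in place of methyl on an aromatic carbon, methylsulfanyl entering where methyl leaves, on an aromatic carbon of a six-membered aromatic ring with 1 nitrogen, two atoms from the ring nitrogen. For the measured compounds named here, nothing among the measured compounds shows the effect of this exchange, so the expectation rests on the nearby values alone. The step expected here is a number 6 percentage points higher from compound 1 to compound 4 (within the scatter), small and not beyond the scatter. Compound 4 is estimated at 48%, within a range from 30% to 66%.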

Compound 4, a percentage reported as inhibition, in the whole organism at one dose (the size of the read-out at that dose, not a potency): 29%
The estimate for compound 4 lay 19 percentage points above the measured number; measured number below the stated range.
By their numbers in this assay, from the lowest: compound 4; then compound 1; then compound 3; then compound 2.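

In this assay, for the compounds shown here, the exchange of methyl for methylsulfanyl gives a number 13 percentage points lower from compound 1 to compound 4 (beyond the scatter) on this aromatic carbon, two atoms from the ring nitrogen, and this is the first step that can be counted. This carbon is therefore not indifferent to the group it carries: here, one added sulfur atom and one added hydrogen-bond acceptor go with less inhibition at the dose given. No measurement at hand bears on the reason for this step.

A single exchange cannot show whether the step follows the sulfur atom itself or simply the larger group. Methoxy, an amine or a chlorine atom on the same carbon remain open, as does a longer chain such as ethylsulfanyl.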